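The source may hold more compounds than are shown below. What is called first, only, known or untested is meant among the compounds shown, and "the series" means these compounds.

Working notes on a small series compared in an ADME assay on K562 cells (Homo sapiens) for cytotoxicity, with a stated time of 72 h; on this read-out higher numbers stand for weaker inhibition and lower numbers for stronger inhibition. Compound 1 `Oc1ccccc1CNc1ncnc2c1ncn2C1CCCCO1` carries a hydroxy group on its aryl ring. In this assay compound 1 gives only a limit of the assay, > 100000 nM. Compound 2 `COc1cccc(CNc2ncnc3c2ncn3C2CCCCO2)c1O` differs from compound 1 by methoxy in place of hydrogen on an aromatic carbon. In this assay compound 2 also gives only a limit, > 100000 nM. Accordingly the step that the two limits leave unreadable from compound 1 to compound 2 cannot be read. Compound 3 `COc1cc(CNc2ncnc3c2ncn3C2CCCCO2)cc(OC)c1` belongs to the same series; how its core differs from the core of compound 1 is not broken down here. In this assay compound 3 again gives only a limit, > 100000 nM. Compound 4 `COc1cc(CNc2ncnc3c2ncn3C2CCCCO2)cc(OC)c1OC` is not yet measured and differs from compound 3 by methoxy in place of hydrogen on an aromatic carbon. This is the same kind of change as that from compound 1 to compound 2, though the place is not the same: in compound 2 the methoxy enters ortho to a hydroxy group and meta to a large group, in compound 4 ortho to two methoxy groups and para to a large group. All measured values sit at the limit of > 100000 nM in this assay, at which 3 of the 3 values shown sit. The step that the limit leaves unreadable from compound 3 to compound 4 is expected to stay unreadable, since a step that the two limits leave unreadable from compound 1 to compound 2 gave no readable size. For compound 4 the expected result is 150000 nM, most likely reported as a limit again.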

Compound 4, half-maximal inhibitory concentration: > 100000 nM
Compound 4: a limit, no number; the forecaster's own chance of this, stated with the estimate: 85%; the middle value does not contradict the limit.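

No new step can be read: compound 3 and compound 4 both give only a limit in this assay, so methoxy in place of hydrogen on an aromatic carbon has no readable size here. The compounds shown leave open whether any change on the shared core gives a readable number, since all results remain at one limit: the limit of > 100000 nM in this assay, at which 4 of the 4 values shown sit.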